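Replacing an amide by a hydroxypropyl chain on the shared core

The source may report more compounds than this note shows. Statements on the series, on what has been measured and on what is new or still open speak of the compounds shown alone.

Measured compounds:
- compound 1 `Fc1ccccc1Cn1nnc2c(NC3CC3)nc(-c3ccccc3)nc21` — 15000000 nM
- compound 2 `OCCCNc1nc(-c2ccccc2)nc2c1nnn2Cc1ccccc1` — 21400000 nM
- compound 3 `COc1ccc(C(=O)Nc2nc(-c3ccccc3)nc3c2nnn3Cc2ccccc2F)cc1` — 21900000 nM

In an assay on isolated protein for binding affinity to adenosine receptor A1 (Bos taurus) (on this read-out higher numbers stand for weaker inhibition and lower numbers for stronger inhibition), compound 3 gives the highest of the three numbers, yet its distance to compound 2 and to compound 1 lies within the scatter, so no order among them can be read. Compound 4 `OCCCNc1nc(-c2ccccc2)nc2c1nnn2Cc1ccccc1F` differs from compound 3 by 3-hydroxypropyl in place of (4-methoxyphenyl)carbonyl on a nitrogen on an aromatic ring. Among the compounds with values here, one measured step touches this nitrogen: a 1.5-fold higher number from compound 1 to compound 3 (0.16 log units; within the scatter). Compound 2, which already carries the 3-hydroxypropyl group, shows a number close to that of compound 3. The step to compound 4 is therefore expected to stay within the scatter, a 1.1-fold lower number from compound 3 to compound 4 (0.04 log units; within the scatter). Compound 4 is estimated at 20000000 nM, with a range from 8000000 nM to 50000000 nM.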

Compound 4, inhibition constant: 3700000 nM
Estimate against measurement, compound 4: 5.4-fold (0.73 log units) above; measured number outside the range, below it.
By their numbers in this assay, from the lowest: compound 4; then compounds 1, 2 and 3 (each within the scatter of the next).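

In this assay, the group on this nitrogen now makes a difference beyond the scatter, with 3-hydroxypropyl giving a 5.9-fold lower number from compound 3 to compound 4 (0.77 log units; beyond the scatter) against (4-methoxyphenyl)carbonyl and a 4.1-fold lower number from compound 1 to compound 4 (0.61 log units; beyond the scatter) against cyclopropyl. With 3-hydroxypropyl on the nitrogen, fluoro in place of hydrogen on an aromatic carbon also counts, giving a 5.8-fold lower number from compound 2 to compound 4 (0.76 log units; beyond the scatter). Compound 4 therefore has the lowest number of the series, and the only one set apart from the others beyond the scatter.

No measurement given here accounts for these steps. Open questions are whether a longer chain or a terminal amine would hold this gain, and whether fluoro has the same effect with other groups on the nitrogen.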